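The source may hold more compounds than are shown below. What is called first, only, known or untested is meant among the compounds shown, and "the series" means these compounds.

Measured so far:
- Compound 1, `O=c1oc(Nc2ccccc2I)nc2cccc(Cl)c12`: 14500 nM
- Compound 2, `O=c1oc(Nc2ccccc2I)nc2cc(Cl)ccc12`: 700 nM

Both compounds share one core and differ only in where a single chloro group sits on it. In an assay on isolated protein for inhibition of complement C1r subcomponent (Homo sapiens) (on this read-out higher numbers stand for weaker inhibition and lower numbers for stronger inhibition), compound 1 gives 14500 nM, while compound 2 gives 700 nM. Compound 2 therefore stands with the lower of the two numbers, and its gap to compound 1 lies beyond the usual scatter.

Compound 3, `O=c1oc(Nc2ccccc2I)nc2cc(Cl)cc(Cl)c12`, has not yet been measured. It keeps everything in compound 2 and adds one more group: chloro in place of hydrogen on an aromatic carbon. In effect it carries the chloro groups of both measured compounds at once. Among the measured compounds shown here, no single-change pair among the measured compounds shows what this particular addition does, so the expectation rests only on the two values given. Since compound 1 is the weaker of the pair, a step of no size beyond the scatter, or a modest move toward a higher number, is expected for a 1.7-fold higher number from compound 2 to compound 3 (0.23 log units; within the scatter). Compound 3 is thus estimated at 1200 nM in this assay, with a range from 300 nM to 5000 nM.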

Compound 3, half-maximal inhibitory concentration: > 62500 nM
Compound 3 gave a limit, no number; the forecaster's own chance of this, stated with the estimate: 5%; middle value at least 52-fold (1.71 log units) away from the limit.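

In this assay, the reading for compound 3 is a limit, not a number: the limit of > 62500 nM in this assay, at which 1 of the 3 values shown sits.

Adding chloro in place of hydrogen on an aromatic carbon, ortho to a fused ring, gives an at least 89-fold higher number from compound 2 to compound 3 (1.95 log units; beyond the scatter), while adding chloro in place of hydrogen on an aromatic carbon elsewhere on the shared core gives an at least 4.3-fold higher number from compound 1 to compound 3 (0.63 log units; beyond the scatter). A single added chlorine atom at this position is therefore enough for a large loss in compound 2, and carrying both chloro groups together reads weaker than carrying either one alone.

The compounds shown do not reveal why this happens. Going by these compounds, it also remains open whether fluoro, methoxy or an amine at this position would bring the same loss, and whether the loss would persist if the iodo group were replaced by methyl.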